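A few compounds are considered here, and "the series" means these few. Any claim that something is new, unique, unknown or untested is made for them only; others in the source may bear on it.

In a physicochemical assay for lipophilicity, read by HPLC (a higher number here means a more lipophilic compound, a lower number a more polar compound), two compounds sharing one core have been measured so far. Compound 1 `O=C1/C(=C/c2ccncc2)C(c2ccccc2)Oc2ccccc21` gives 2.98, and compound 2 `O=C1/C(=C/c2ccc(Cl)cc2)C(c2ccccc2)Oc2ccccc21` gives 4.46, the higher of the two numbers. Compound 3 `O=C1/C(=C/c2ccc(Br)cc2)C(c2ccccc2)Oc2ccccc21` differs from compound 2 by one swap, bromo in place of chloro on an aromatic carbon. The swap sits on an aromatic carbon of a six-membered aromatic ring of carbon only, para to a large group. For the measured compounds named here, only one measured step is available, a number 1.48 log units higher from compound 1 to compound 2 (beyond the scatter), which is large and beyond the scatter. Going by the values given here, that step puts 4-chlorophenyl in place of pyridin-4-yl, a much bigger exchange, and no measured pair shows chloro going to bromo. Only a small rise in this assay is therefore expected, probably within the scatter. The expected change is a number 0.14 log units higher from compound 2 to compound 3 (within the scatter). Compound 3 is estimated at 4.6, with an expected range from 4.35 to 4.9.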

Compound 3, partition coefficient: 4.46
The estimate for compound 3 lay 0.14 log units above the measured number; the range from low to high includes it.
By their numbers in this assay, from the lowest: compound 1; then compounds 2 and 3 (each within the scatter of the next).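

In this assay, bromo in place of chloro on an aromatic carbon, para to a large group, shows no change at the digits printed from compound 2 to compound 3 (within the scatter), so this read-out does not separate these two halogens at this position. The exchange of pyridin-4-yl for 4-bromophenyl shows a number 1.48 log units higher from compound 1 to compound 3 (beyond the scatter), matching the earlier exchange for 4-chlorophenyl, a number 1.48 log units higher from compound 1 to compound 2 (beyond the scatter), so the large step is not peculiar to chloro and is seen with both halogens. Nothing available explains why the two halogens read alike.

On these data alone, whether fluoro or iodo on the same carbon would also read like chloro and bromo remains open. So does the reading with a group of a different kind there, such as an amine, a carboxylic acid or a longer carbon chain.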